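Alkyne aryl swap in the hydroxyamide series: efficacy outlook

The compounds below may be only part of what the source reports. "The series", "measured", "known", "first", "only" and "open" are said of these compounds alone.

Of the compounds shown here, two have been measured in an ADME assay on HEK293 cells for agonist activity at metabotropic glutamate receptor 5 (Rattus norvegicus), read by fluorescence and calcium flux; a lower number here means a smaller maximal response, a higher number a larger maximal response. Compound 1 `C[C@@H](NC(=O)c1ccc(C#Cc2ccccc2F)cn1)C(C)(C)O` gives 29.6%. Compound 2 `C[C@@H](NC(=O)c1ccc(C#Cc2ccc(F)cc2F)cn1)C(C)(C)O` gives 38.2%. Among the measured compounds shown here, compound 2 therefore holds the higher of the two numbers, but its only neighbour is compound 1, and the step of a number 8.6 percentage points higher from compound 1 to compound 2 (within the scatter) lies within the scatter, so the two are not distinguished by this assay.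

Compound 3 `Cc1cccc(C#Cc2ccc(C(=O)N[C@H](C)C(C)(C)O)nc2)c1` differs from compound 2 by 3-methylphenyl in place of 2,4-difluorophenyl on a triple-bonded carbon. For the measured compounds named here, no measured step matches this exchange: the one step known, a number 8.6 percentage points higher from compound 1 to compound 2 (within the scatter), concerns fluoro in place of hydrogen on the same aryl ring and changed nothing beyond the scatter. Going by the values given here, the exchange to 3-methylphenyl removes both fluorines and adds a methyl, which no measured pair covers, so the basis for a directional expectation is absent.

In this assay compound 3 is therefore expected to land near the two measured numbers, estimated at 33% with a range from 12% to 56%. Among the compounds with values here, the implied step from compound 2 is expected to be a number 5.2 percentage points lower from compound 2 to compound 3 (within the scatter), not beyond the scatter, with the range kept wide since the aryl change has no precedent here.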

Compound 3, largest response reached (reported as efficacy), in percent of the reference or control that the assay uses: 20.8%
For compound 3 the middle estimate is 12.2 percentage points above the measured one, and the stated range covers the measured number.
By their numbers in this assay, from the lowest: compounds 3, 1 and 2 (each within the scatter of the next, the first and the last beyond it).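

Among the compounds shown here, at the aryl group on the triple-bonded carbon, this assay now separates two compounds: with 3-methylphenyl in place of 2,4-difluorophenyl, the result is a number 17.4 percentage points lower from compound 2 to compound 3 (beyond the scatter) and is the first step here to lie beyond the scatter. The same group in place of 2-fluorophenyl gives a number 8.8 percentage points lower from compound 1 to compound 3 (within the scatter) and does not separate those two compounds, so the change registers only against the 2,4-difluorophenyl compound, and only modestly. No measurement at hand offers an explanation for this step.

Whether the step follows the entering methyl or the departing fluorines stays open, as this exchange changes both at once and no compound shown separates them. Also open, as far as these compounds go, is how this assay would read a plain phenyl, or an aryl group bearing an amine or a carboxylic acid, on the same triple-bonded carbon.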